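Swapping a methoxy for a fluoro on a shared core

The source may hold more compounds than are shown below. What is called first, only, known or untested is meant among the compounds shown, and "the series" means these compounds.

Three compounds have been measured in a functional assay on 786-0 cells (Homo sapiens) for inhibition, read by sulforhodamine B assay, with a stated time of 48 h; on this read-out higher numbers stand for weaker inhibition of growth and lower numbers for stronger inhibition of growth:
compound 1, `CCOC(=O)[C@H](CCC(=O)O)NC(=O)c1ccc(Sc2nc3cc(N)cc(N)c3nc2-c2ccccc2)cc1`, gives 24500 nM
compound 2, `COc1cc(CNc2nc3cc(N)cc(N)c3nc2-c2ccccc2)cc(OC)c1OC`, gives 15500 nM
compound 3, `COc1ccc(Sc2nc3cc(N)cc(N)c3nc2-c2ccccc2)cc1`, gives 13200 nM

All three share the same core and differ only in the group hung from it. Going by the values given here, on the numbers so far, compound 3 has the lowest of the three values, but that says little: compound 2 sits so close that the two cannot be told apart within the usual scatter of this assay, and even compound 1, the furthest away, still lies within that scatter. Among the compounds with values here, no compound among the three can be called the most or least active; on this read-out they look alike.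

Compound 4, `Nc1cc(N)c2nc(-c3ccccc3)c(Sc3ccc(F)cc3)nc2c1`, has not yet been measured. It differs from compound 3 in one place only: fluoro in place of methoxy on an aromatic carbon. Within the data shown here, no pair of measured compounds shows this same change, so there is nothing in the set to lean on for its size. The expectation is therefore a step of no size beyond the scatter, a 1.1-fold higher number from compound 3 to compound 4 (0.03 log units; within the scatter). Compound 4 is estimated to give 14000 nM, somewhere between 5000 nM and 40000 nM.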

Compound 4, concentration for 50% growth inhibition: < 100000 nM
Compound 4: a limit, no number (the forecaster's own chance of this, stated with the estimate: 15%); the middle value lies beyond the limit too.
By their numbers in this assay, from the lowest: compounds 3, 2 and 1 (each within the scatter of the next).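

In this assay, going by these compounds alone, compound 4 gives < 100000 nM, which is a limit of the assay and not a number, so no step between compound 3 and compound 4 can be read. The compounds shown leave open whether fluoro in place of methoxy on an aromatic carbon changes growth inhibition at all, and in which direction.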